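The compounds below may be only part of what the source reports. "The series", "measured", "known", "first", "only" and "open" are said of these compounds alone.

Measured compounds in a functional assay on the whole organism (blood, strain Wistar-Okamoto) with Rattus norvegicus as the target, with a stated time of 5 days; on this read-out higher numbers stand for an effect only at larger amounts of compound and lower numbers for an effect already at smaller amounts:
compound 1, `CCC(C)(C)N/C(=N\C(N)=O)Nc1cccnc1`, gives > 50 mg/kg, which is a limit of the assay and not a number.
compound 2, `CCC(C)(C)N/C(=N\C(=O)C(F)(F)F)Nc1cccnc1`, gives > 50 mg/kg, again a limit of the assay.
compound 3, `CCC(C)(C)N/C(=N\c1cnccn1)Nc1cccnc1`, gives 25 mg/kg.

Going by the values given here, compound 3 therefore holds the only number; the two other values sit at the limit (the limit of > 50 mg/kg in this assay, at which 2 of the 3 values shown sit). The steps that reach it are floors rather than sizes: an at least 2.0-fold lower number from compound 1 to compound 3 (0.30 log units; that floor lies within the scatter) and an at least 2.0-fold lower number from compound 2 to compound 3 (0.30 log units; that floor lies within the scatter), both resting on a limit, so neither says more than that compound 3 reads as a number where the others do not. The step that the two limits leave unreadable from compound 1 to compound 2 is unreadable from the two limits.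

Compound 4, `CCC(C)(C)N/C(=N\c1ncccn1)Nc1cccnc1`, is the next member to be measured. It differs from compound 3 in one place: pyrimidin-2-yl in place of pyrazin-2-yl on a double-bonded nitrogen. Among the compounds with values here, none of the three measured steps exchanges one six-membered aromatic ring with two heteroatoms for another, so no measured step speaks directly to this change; what bears on compound 4 is only the number of compound 3 itself, 25 mg/kg. With the same atoms joined differently, no step beyond the scatter is expected in this assay , and the expected step is no change at the digits printed from compound 3 to compound 4 (within the scatter). Compound 4 is accordingly estimated at 25 mg/kg, within a range of 10 mg/kg to 60 mg/kg.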

Compound 4, minimum effective dose: > 35 mg/kg
Compound 4 was reported as a limit; the forecaster's own chance of this, stated with the estimate: 35%; middle value at least 1.4-fold (0.14 log units) from the limit.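

Going by these compounds alone, exchanging pyrazin-2-yl for pyrimidin-2-yl on a double-bonded nitrogen is the first change between two rings of the same atoms, and in this assay it yields only a floor, an at least 1.4-fold higher number from compound 3 to compound 4 (0.14 log units; that floor lies within the scatter), so the data neither establish a real difference between the two rings nor show that they read alike. Compound 4 carries a limit of the assay and not a number, and it adds a second limit to the series: the limit of > 35 mg/kg in this assay, at which 1 of the 4 values shown sits. Within the data shown here, the steps from compound 1 and from compound 2 to compound 4 cannot be read, as each joins two limits, so compound 3 remains the only member with a number and pyrimidin-2-yl cannot yet be placed against carbamoyl or (trifluoromethyl)carbonyl.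

Still open, on these data alone, is whether a true number for compound 4 would lie within the scatter of compound 3 or clearly apart from it. Also open, as far as these compounds go, is how a nitrile or a pyridin-2-yl on the same double-bonded nitrogen would read in this assay, and thus whether any ring there gives a number more generally.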